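Swapping the Aryl Group on the Shared Core

This account rests on a few compounds, and the source may have more. Where it says the series, first, only, none or still open, it means among the compounds named here.

Compound 3 `Cc1cc(O)c(C(C)C)cc1-c1cc(-c2ccc(N(C)C)cc2)c(C#N)c(=O)[nH]1` gives 43% in a functional assay for inhibition, tested at 40 ug/mL; a lower number here means a weaker effect, a higher number a stronger effect of the compound at the concentration tested. Among the compounds with values here, that is the highest of the three numbers measured so far, though the nearest, compound 2 `Cc1cc(O)c(C(C)C)cc1-c1cc(-c2ccco2)c(C#N)c(=O)[nH]1` with 42.5%, lies within the scatter of it, so those two cannot be put in order; only compound 1 `COc1cc(-c2cc(-c3cc(C(C)C)c(O)cc3C)[nH]c(=O)c2C#N)ccc1O` with 32% sits clearly lower, as the step of a number 11 percentage points higher from compound 1 to compound 3 (beyond the scatter) shows. Compound 4 `Cc1cc(O)c(C(C)C)cc1-c1cc(-c2ccccc2Cl)c(C#N)c(=O)[nH]1` differs from compound 3 in one place: 2-chlorophenyl in place of 4-(dimethylamino)phenyl on an aromatic carbon. All three measured steps change the group at this same aromatic carbon. a number 10.5 percentage points higher from compound 1 to compound 2 (beyond the scatter) and a number 11 percentage points higher from compound 1 to compound 3 (beyond the scatter) were modest gains beyond the scatter, whereas a number 0.5 percentage points higher from compound 2 to compound 3 (within the scatter) stayed within it. Changing the aryl group here has therefore moved the read-out only modestly, and nothing measured bears on a 2-chlorophenyl group in particular. For compound 4 a step of a number 5 percentage points lower from compound 3 to compound 4 (within the scatter) is expected, a small drop that stays within the scatter. Compound 4 is estimated at 38%, between 24% and 52%.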

Compound 4, a percentage reported as inhibition, at one concentration (the size of the read-out at that concentration, not a potency): 20%
For compound 4 the middle estimate is 18 percentage points above the measured one, and the stated range ends above it.
By their numbers in this assay, from the lowest: compound 4; then compound 1; then compounds 2 and 3 (each within the scatter of the next).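

This position proved more sensitive in this assay than compounds 1, 2 and 3 had indicated, since 2-chlorophenyl brings a larger change than any step among them, both against 4-(dimethylamino)phenyl (a number 23 percentage points lower from compound 3 to compound 4 (beyond the scatter)) and against furan-2-yl (a number 22.5 percentage points lower from compound 2 to compound 4 (beyond the scatter)). The 4-hydroxy-3-methoxyphenyl group no longer gives the lowest number at this aromatic carbon (a number 12 percentage points lower from compound 1 to compound 4 (beyond the scatter)), so compound 4 now stands clearly below all the others. Nothing available here gives a reason for this drop.

The compounds shown leave open whether the lower number goes with the chlorine itself or with where it sits on the phenyl ring, which an unsubstituted phenyl or a 4-chlorophenyl group would help to separate. As far as these compounds go, how a carboxylic acid or an aliphatic amine at this carbon would read also remains open.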